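Swapping the fluoropyridine for a methylthiazole on the amine

A few compounds are considered here, and "the series" means these few. Any claim that something is new, unique, unknown or untested is made for them only; others in the source may bear on it.

Of the compounds shown here, three sharing one core have been tested in a functional assay on HEK293 cells for negative allosteric modulation of metabotropic glutamate receptor 5 (Homo sapiens), read by HTRF and inositol phosphate accumulation; a lower number here means a stronger inhibitor, a higher number a weaker inhibitor. Compound 1 `C=CC[C@@H](NC(=O)c1nccs1)c1cnc(Nc2ccc(C)nc2)c(Cl)c1` gives 2.4 nM. Compound 2 `CCC[C@@H](NC(=O)c1nccs1)c1cnc(Nc2cccnc2)c(Cl)c1` gives 71.4 nM. Compound 3 `CCC[C@@H](NC(=O)c1nccs1)c1cnc(Nc2ccc(F)nc2)c(Cl)c1` gives 12.8 nM. Within the data shown here, the only single-point comparison among them is a 5.6-fold lower number from compound 2 to compound 3 (0.75 log units; beyond the scatter). On these numbers compound 3 sits in the middle: compound 2 shows a higher number and compound 1 a lower one, both gaps beyond the scatter.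

Compound 4 `CCC[C@@H](NC(=O)c1nccs1)c1cnc(Nc2cnc(C)s2)c(Cl)c1` is built from compound 3 by one change: 2-methyl-1,3-thiazol-5-yl in place of 6-fluoropyridin-3-yl on a nitrogen on an aromatic ring. Among the measured compounds shown here, no measured step swaps the whole aromatic ring on that nitrogen; the one step that touches this ring, from compound 2 to compound 3, only changes a single substituent on it, so it gives no direct guide. Without a matching step, no direction beyond the scatter can be claimed for this assay, and the uncertainty is wide. Compound 4 is expected to give roughly 15 nM, somewhere between 4 nM and 60 nM. The expected step is a 1.2-fold higher number from compound 3 to compound 4 (0.07 log units; within the scatter), which is not beyond the scatter.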

Compound 4, half-maximal inhibitory concentration: 60 nM
Compound 4: middle estimate off by 4.0-fold (0.60 log units), on the low side; the range from low to high includes it.
By their numbers in this assay, from the lowest: compound 1; then compound 3; then compounds 4 and 2 (each within the scatter of the next).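

In this assay, the result shows that the whole ring on this nitrogen matters and not only the single substituent changed earlier: 2-methyl-1,3-thiazol-5-yl in place of 6-fluoropyridin-3-yl gives a clear loss (a 4.7-fold higher number from compound 3 to compound 4 (0.67 log units; beyond the scatter)), so the advantage held by the fluoropyridine is not kept by this five-membered ring. Measured against the plain pyridin-3-yl, the same thiazole gives no real difference (a 1.2-fold lower number from compound 2 to compound 4 (0.08 log units; within the scatter)), which places the methylthiazole level with the unsubstituted pyridine and leaves the 6-fluoropyridin-3-yl of compound 3 ahead of both. Nothing available here explains why these rings give such different numbers.

Going by these compounds, what remains open is whether the ring itself or its methyl group sets the number of compound 4, and a thiazole carrying fluoro in place of that methyl would be the direct way to separate the two. On these data alone, it is also open how a methoxy group on the pyridine, or a pyrazole ring on the same nitrogen, would compare with compound 3 in this assay on this shared core.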